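Replacing 3-methoxyphenyl with 3-chlorophenyl in the amide series

The source may report more compounds than this note shows. Statements on the series, on what has been measured and on what is new or still open speak of the compounds shown alone.

In a physicochemical assay for lipophilicity, read by mass spectrometry (a lower number here means a more polar compound, a higher number a more lipophilic compound), compound 3 (`COc1cccc(NC(=O)C2Cc3cc(OC)c(OC)cc3C2=O)c1`) stands at 2.08 and level with compound 1 (`COc1ccc(NC(=O)C2Cc3cc(OC)c(OC)cc3C2=O)cc1`) at 2.08 while compound 2 (`CCc1cccc(NC(=O)C2Cc3cc(OC)c(OC)cc3C2=O)c1`) reads 3.11 as the highest of the three. Compound 4 (`COc1cc2c(cc1OC)C(=O)C(C(=O)Nc1cccc(Cl)c1)C2`) carries chloro in place of methoxy on an aromatic carbon. Going by the values given here, two measured steps bear on this change. Exchanging 4-methoxyphenyl for 3-methoxyphenyl gave no change at the digits printed from compound 1 to compound 3 (within the scatter) and so offers no guide to size. The only measured replacement of this methoxy is ethyl, seen in reverse as a number 1.03 log units lower from compound 2 to compound 3 (beyond the scatter) and large in size. A rise in this assay is expected, smaller than that large step, with an estimated a number 0.67 log units higher from compound 3 to compound 4 (beyond the scatter) as the working figure. Compound 4 is expected between 2.4 and 3.1 with 2.75 as the estimated middle.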

Compound 4, partition coefficient: 2.76
The estimate for compound 4 lay 0.01 log units below the measured number, and the stated range covers the measured number.
By their numbers in this assay, from the lowest: compounds 1 and 3 (each within the scatter of the next); then compound 4; then compound 2.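

In this assay, chloro on this aromatic carbon lands between the two groups seen here, a number 0.68 log units higher from compound 3 to compound 4 (beyond the scatter) against methoxy and a number 0.35 log units lower from compound 2 to compound 4 (beyond the scatter) against ethyl, so this position separates all three groups. Measured from the 4-methoxyphenyl amide, the change is the same size, a number 0.68 log units higher from compound 1 to compound 4 (beyond the scatter) in this series. No measurement here explains this order. Where an amine or a carboxylic acid on this carbon would fall remains open. So does whether 4-chlorophenyl reads level with 3-chlorophenyl, as the two methoxyphenyl amides do.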